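Changing the aryl group on compound 3

The compounds below may be only part of what the source reports. "The series", "measured", "known", "first", "only" and "open" are said of these compounds alone.

Within the data shown here, in a functional assay on MDA-MB-231 cells (Homo sapiens) for cytotoxicity, read by MTT assay, with a stated time of 72 h (on this read-out higher numbers stand for weaker inhibition and lower numbers for stronger inhibition), three compounds with a shared core have numbers so far. Compound 1 (`O=C(CN1CCN(c2nnc(Cc3ccccc3)c3ccccc23)CC1)Nc1c(F)cccc1F`) gives 5490 nM, compound 2 (`O=C(CN1CCN(c2nnc(Cc3ccccc3)c3ccccc23)CC1)Nc1ccc(F)c(F)c1`) gives 2750 nM, and compound 3 (`O=C(CN1CCN(c2nnc(Cc3ccccc3)c3ccccc23)CC1)Nc1ccc(Br)cc1`) gives 12400 nM. Compound 3 has the highest number and is thus the weakest of the three, as a 2.3-fold higher number from compound 1 to compound 3 (0.35 log units; beyond the scatter) and a 4.5-fold higher number from compound 2 to compound 3 (0.65 log units; beyond the scatter) show. The remaining pair cannot be ranked, since a 2.0-fold lower number from compound 1 to compound 2 (0.30 log units; within the scatter) is no larger than ordinary repeat variation.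

Compound 4 (`Cc1cccc(Cl)c1NC(=O)CN1CCN(c2nnc(Cc3ccccc3)c3ccccc23)CC1`) keeps the same core and carries one change, 2-chloro-6-methylphenyl in place of 4-bromophenyl on an amide-type nitrogen. All three measured steps change this same group. The best guide is compound 1, whose 2,6-difluorophenyl group carries the same position numbers in its name as 2-chloro-6-methylphenyl, and its step to 4-bromophenyl was a 2.3-fold higher number from compound 1 to compound 3 (0.35 log units; beyond the scatter). Read backwards, that step suggests a modest fall in the number, though no measured compound here carries chlorine or methyl on this ring. The expected size is a 1.9-fold lower number from compound 3 to compound 4 (0.28 log units; within the scatter), and the step could still prove too small to stand out from the scatter. In this assay, compound 4 is estimated at 6500 nM, with an expected range from 2500 nM to 16000 nM.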

Compound 4, half-maximal inhibitory concentration: 3920 nM
Estimate against measurement, compound 4: 1.7-fold (0.22 log units) above; measured number inside the range.
By their numbers in this assay, from the lowest: compounds 2, 4 and 1 (each within the scatter of the next); then compound 3.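

Among the compounds shown, only compound 4 carries chlorine and methyl on this ring, and in this assay replacing 4-bromophenyl with 2-chloro-6-methylphenyl on the amide-type nitrogen gives a 3.2-fold lower number from compound 3 to compound 4 (0.50 log units; beyond the scatter), a step that stands clear of ordinary repeat variation. Compound 4 cannot be separated from the two difluorophenyl compounds, with a 1.4-fold higher number from compound 2 to compound 4 (0.15 log units; within the scatter) and a 1.4-fold lower number from compound 1 to compound 4 (0.15 log units; within the scatter), so three differently substituted rings now sit level and compound 3 alone stands apart as the weakest of the four. Nothing here offers a measured explanation for why the 4-bromophenyl compound stands apart from the others.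

The compounds shown leave open whether the chlorine or the methyl matters more in compound 4, since neither 2-chlorophenyl nor 2-methylphenyl appears among them. They also leave open whether compound 3 stands apart through its bromine or through having a single group on the ring, a question that 4-chlorophenyl, 4-methylphenyl or plain phenyl on the same nitrogen could help to settle.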